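Ester side chain variation on a naphthoquinone cytotoxicity series

The source may hold more compounds than are shown below. What is called first, only, known or untested is meant among the compounds shown, and "the series" means these compounds.

Measured compounds:
compound 1 `CC[C@@](C)(O)CC(=O)O[C@H](CC=C(C)C)C1=CC(=O)c2c(O)ccc(O)c2C1=O`: 17900 nM
compound 2 `CCCCC(C)(O)CC(=O)O[C@H](CC=C(C)C)C1=CC(=O)c2c(O)ccc(O)c2C1=O`: 60600 nM
compound 3 `CCC(O)(CC)CC(=O)O[C@H](CC=C(C)C)C1=CC(=O)c2c(O)ccc(O)c2C1=O`: 52000 nM

In a functional assay on HeLa cells (Homo sapiens) for cytotoxicity, read by MTT assay (a lower number here means a stronger inhibitor, a higher number a weaker inhibitor), compound 3 gives 52000 nM, the second highest of the three numbers. Its nearest neighbour is compound 2, and the gap a 1.2-fold lower number from compound 2 to compound 3 (0.07 log units; within the scatter) lies within the scatter, so the two cannot be ordered. Compound 1 is the furthest away, with a 2.9-fold higher number from compound 1 to compound 3 (0.46 log units; beyond the scatter), a step that is modest but beyond the scatter.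

Compound 4 `CCCC(CC(=O)O[C@H](CC=C(C)C)C1=CC(=O)c2c(O)ccc(O)c2C1=O)OC(C)=O` is not yet measured. It differs from compound 3 in one place: 1-acetoxybutyl in place of 1-ethyl-1-hydroxypropyl on a saturated chain carbon bound to a carbonyl carbon.

Within the data shown here, two measured steps bear on this change only in part. Both a 3.4-fold higher number from compound 1 to compound 2 (0.53 log units; beyond the scatter) and a 2.9-fold higher number from compound 1 to compound 3 (0.46 log units; beyond the scatter) show that enlarging the group on the saturated chain carbon bound to the carbonyl carbon gave modestly higher numbers, while a 1.2-fold lower number from compound 2 to compound 3 (0.07 log units; within the scatter) shows that two differently shaped groups of similar size gave numbers within the scatter of each other. Among the measured compounds shown here, no measured pair shows the loss of the hydroxyl and the entry of an acetoxy group. The step of a 1.2-fold higher number from compound 3 to compound 4 (0.06 log units; within the scatter) is therefore expected to be small, most likely within the scatter, with a slight lean toward a higher number. Compound 4 is estimated at 60000 nM, with a range from 22000 nM to 160000 nM.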

Compound 4, half-maximal inhibitory concentration: 51200 nM
For compound 4 the middle estimate is 1.2-fold (0.07 log units) above the measured one, and the stated range covers the measured number.
By their numbers in this assay, from the lowest: compound 1; then compounds 4, 3 and 2 (each within the scatter of the next).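

In this assay, replacing 1-ethyl-1-hydroxypropyl with 1-acetoxybutyl on the saturated chain carbon bound to a carbonyl carbon leaves the number essentially in place (a 1.0-fold lower number from compound 3 to compound 4 (0.01 log units; within the scatter)), and the comparison with 1-hydroxy-1-methylpentyl gives the same picture (a 1.2-fold lower number from compound 2 to compound 4 (0.07 log units; within the scatter)). The earlier compounds shown here all carried a hydroxyl on this group, so compound 4 adds something new: a group with no hydrogen-bond donor and an acetoxy in its place sits level with compound 2 and compound 3, which means the free hydroxyl is not needed to hold the number at that level. Compound 1, with the smaller 1-hydroxy-1-methylpropyl, stays apart from this new member as well (a 2.9-fold higher number from compound 1 to compound 4 (0.46 log units; beyond the scatter)), so among these four compounds it alone has a lower number, and nothing at hand explains this pattern.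

The compounds shown do not separate the swap of hydroxyl for acetoxy from the change in the carbon skeleton, a question that 1-hydroxybutyl at this place would address directly. They also leave open how an amine or a carboxylic acid on this chain would read, and whether any group here could go below compound 1.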